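Methoxy on the nitrogen-bound phenyl of compound 3

A few compounds are considered here, and "the series" means these few. Any claim that something is new, unique, unknown or untested is made for them only; others in the source may bear on it.

Working notes on the series. All three measured compounds share a core bearing two ethyl ester groups and an aryl group on the ring nitrogen. Compound 1 `CCOC(=O)c1c(-c2c(Cl)c3ccccc3oc2=O)nn(-c2ccccc2)c1C(=O)OCC` gives 48000 nM in a functional assay on DU-145 cells (Homo sapiens) for cytotoxicity, read by MTT assay, with a stated time of 48 h; a higher number here means a weaker inhibitor, a lower number a stronger inhibitor. Compound 2 `CCOC(=O)c1c(-c2c(Cl)c3cc(C)ccc3oc2=O)nn(-c2cccc(Cl)c2)c1C(=O)OCC` gives 156000 nM in this assay; it differs from compound 1 in more than one place, so the two values can only be set side by side. Compound 3 `CCOC(=O)c1c(-c2cc3ccccc3oc2=O)nn(-c2ccccc2)c1C(=O)OCC` gives 57000 nM in this assay. Compound 3 stands second highest of the three numbers. Going by the values given here, the one single-point step in the set, a 1.2-fold higher number from compound 1 to compound 3 (0.07 log units; within the scatter), lies within the scatter, so compound 1 and compound 3 cannot be told apart. Compound 2 stands furthest from compound 3, and that gap is beyond the scatter.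

Compound 4 `CCOC(=O)c1c(-c2cc3ccccc3oc2=O)nn(-c2ccc(OC)cc2)c1C(=O)OCC` is the next step: methoxy in place of hydrogen on an aromatic carbon. Among the compounds with values here, no measured single-point step touches the phenyl on the ring nitrogen; the only change there, in compound 2, arrives together with a second change elsewhere, so nothing can be drawn from it alone. There is therefore no basis for expecting movement beyond the scatter in this assay. Compound 4 is expected to give 60000 nM, in the range 25000 nM to 150000 nM. The expected step of a 1.1-fold higher number from compound 3 to compound 4 (0.02 log units; within the scatter) thus stays within the scatter.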

Compound 4, half-maximal inhibitory concentration: 39000 nM
Compound 4: middle estimate off by 1.5-fold (0.19 log units), on the high side; the measured number falls inside the stated range.
By their numbers in this assay, from the lowest: compounds 4, 1 and 3 (each within the scatter of the next); then compound 2.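

Going by these compounds alone, this is the first single-point step read at the phenyl on the ring nitrogen: the change from phenyl to 4-methoxyphenyl gives a 1.5-fold lower number from compound 3 to compound 4 (0.16 log units; within the scatter) in this assay and therefore does not separate the two compounds. At this place on the six-membered aromatic ring, para to a large group, the entering methoxy adds 2 heavy atoms and 1 hydrogen-bond acceptor without a shift that can be read as real. The series now has two single-point steps, this one and a 1.2-fold higher number from compound 1 to compound 3 (0.07 log units; within the scatter) at the chloro position, and both lie within the scatter, while no measurement at hand accounts for the result at the methoxy position.

Within the data shown here, it remains open whether any group at this place can move the number beyond the scatter, since methoxy is the only group here read alone and says nothing about a carboxylic acid or a dimethylamino group in the same position. Also open, from the compounds shown here alone, is whether replacing hydrogen with methoxy would behave alike on the chloro-bearing core of compound 1, or whether a longer chain than methoxy, such as butoxy, would give a larger step.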